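The source may hold more compounds than are shown below. What is called first, only, known or untested is meant among the compounds shown, and "the series" means these compounds.

Working notes on the series. Compound 1 `O=C(CC1CCCCC1)N1CCN(c2nc(=O)c3cc(C(F)(F)F)cc([N+](=O)[O-])c3s2)CC1` carries a cyclohexylmethyl group on the amide carbonyl of the piperazine; compound 2 `O=C(C1CC1)N1CCN(c2nc(=O)c3cc(C(F)(F)F)cc([N+](=O)[O-])c3s2)CC1` carries a cyclopropyl group at the same carbonyl. In an ADME assay on Vero cells (Chlorocebus sabaeus) for cytotoxicity, read by MTT assay, with a stated time of 72 h (a higher number here means that more compound is tolerated, a lower number that less compound is tolerated), compound 1 gives > 125000 nM, which is a limit of the assay rather than a number. In this assay compound 2 likewise gives > 125000 nM, also a limit of the assay. The step that the two limits leave unreadable from compound 1 to compound 2 therefore cannot be read as a size in either direction. Where compound 2 stands is thus known only as a limit, and the one further value shown is a limit as well, so the evidence on the measured steps amounts to the limit of > 125000 nM in this assay, at which 2 of the 2 values shown sit.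

Compound 3 `O=C(c1cccc(F)c1)N1CCN(c2nc(=O)c3cc(C(F)(F)F)cc([N+](=O)[O-])c3s2)CC1` is the next member. It differs from compound 2 in one place: 3-fluorophenyl in place of cyclopropyl on a carbonyl carbon. Within the data shown here, the single measured step bears on the same carbonyl position but is unreadable in size, so it gives no direction. With both shown values sitting at the limit, the step that the limit leaves unreadable from compound 2 to compound 3 is expected to be none beyond the scatter, and compound 3 is estimated at 150000 nM in this assay, within 60000 nM to 400000 nM, most probably reported again as a limit.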

Compound 3, half-maximal cytotoxic concentration: > 125000 nM
Compound 3: no number, only a limit; the forecaster's own chance of this, stated with the estimate: 80%; the middle value lies beyond the limit too.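

In this assay compound 3 gives > 125000 nM, again a limit of the assay and not a number. Among these compounds, no step among compound 1, compound 2 and compound 3 can therefore be read in size. The compounds shown leave open how these three differ in this assay, and whether any group on the carbonyl gives a readable value.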